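This account rests on a few compounds, and the source may have more. Where it says the series, first, only, none or still open, it means among the compounds named here.

The series shares one core, shown by compound 1 `Cc1ccc2nc(Cl)c(/C=N/n3cc(-c4ccccc4)nc3N)cc2c1`, and is followed in a functional assay on HCT-116 cells (Homo sapiens) for cytotoxicity, read by MTT assay, with a stated time of 48 h; on this read-out higher numbers stand for weaker inhibition and lower numbers for stronger inhibition. In this assay compound 1 gives 7120 nM. Compound 2 `Nc1nc(-c2cccc3ccccc23)cn1/N=C/c1cc2ccccc2nc1Cl` carries a larger aromatic group on the same position and in this assay compound 2 gives 6340 nM, a number that sits within the usual scatter of the value for compound 1, so the two cannot be told apart. Among the measured compounds shown here, compound 3 `Nc1nc(-c2ccc3ccccc3c2)cn1/N=C/c1cc2ccccc2nc1Cl` is the one member of the set for which only a limit is reported: in this assay compound 3 gives > 50000 nM, and this is a limit of the assay rather than a number. That limit, (the limit of > 50000 nM in this assay, at which 1 of the 3 values shown sits), is the single case of its kind among the three values shown.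

Compound 4 `Cc1ccc2nc(Cl)c(/C=N/n3cc(-c4cccs4)nc3N)cc2c1` has not been measured. It differs from compound 1 by thiophen-2-yl in place of phenyl on an aromatic carbon. For the measured compounds named here, no pair of measured compounds differing in only this one place is available, so the expectation rests on the exchange itself, which swaps one small aromatic ring for another of closely similar size. The step from compound 1 to compound 4 is therefore expected to be a 1.0-fold lower number from compound 1 to compound 4 (0.01 log units; within the scatter), none beyond the scatter in either direction. On that basis compound 4 is estimated to give 7000 nM in this assay, with a range from 2500 nM to 20000 nM.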

Compound 4, half-maximal inhibitory concentration: 7710 nM
For compound 4 the middle estimate is 1.1-fold (0.04 log units) below the measured one; the measured number falls inside the stated range.
By their numbers in this assay, from the lowest: compounds 2, 1 and 4 (each within the scatter of the next). At a limit, above all of these: compound 3.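

Among the compounds shown here, this is the first step in the set that can be read at one place: on an aromatic carbon of the five-membered aromatic ring with 2 nitrogen, thiophen-2-yl in place of phenyl gives, in this assay, a 1.1-fold higher number from compound 1 to compound 4 (0.03 log units; within the scatter). The position thus takes a five-membered aromatic ring with 1 hetero atom, which brings in a sulfur and a hydrogen-bond acceptor that phenyl does not have, with no change that can be told from the scatter, so this one exchange gives no sign that the ring size or the sulfur matters for this read-out. Nothing in the data given speaks to why the number stays where it does.

What an amine, a carboxylic acid or a longer chain would do on this same aromatic carbon stays open, since all the groups shown there are aromatic rings. From the compounds shown here alone, it is also open whether thiophen-2-yl in place of phenyl would give the same result on the core of compound 2, or in a read-out other than this assay.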